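Swapping 4-hydroxy-2-methylphenyl for 4-ethylphenyl in compound 2

This account rests on a few compounds, and the source may have more. Where it says the series, first, only, none or still open, it means among the compounds named here.

Compound 1 `Cc1ccc(C2=NN(c3ccc(S(C)(=O)=O)cc3)C(=O)CC2)cc1` and compound 2 `Cc1cc(O)ccc1C1=NN(c2ccc(S(C)(=O)=O)cc2)C(=O)CC1` share one core. In a functional assay on CCRF-CEM cells (Homo sapiens) for inhibition, read by sulforhodamine B assay, with a stated time of 48 h (on this read-out lower numbers stand for stronger inhibition of growth and higher numbers for weaker inhibition of growth), compound 1 gives 1160 nM, while compound 2 gives 9090 nM. Compound 2 therefore holds the higher of the two numbers and is the weaker growth inhibitor of the pair. Among the measured compounds shown here, the only measured step is a 7.8-fold higher number from compound 1 to compound 2 (0.89 log units; beyond the scatter), a modest change that came with 4-hydroxy-2-methylphenyl in place of 4-methylphenyl on a carbon with a double bond to nitrogen.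

Compound 3 `CCc1ccc(C2=NN(c3ccc(S(C)(=O)=O)cc3)C(=O)CC2)cc1` carries a change at that same place: 4-ethylphenyl in place of 4-hydroxy-2-methylphenyl on a carbon with a double bond to nitrogen. There, 4-ethylphenyl stands in place of 4-hydroxy-2-methylphenyl, so the group that arrived in the measured step leaves again. For the measured compounds named here, the step from compound 1 is the sole guide, and a move back toward a lower number of similar size is expected. Going by the values given here, no measured compound carries 4-ethylphenyl, so its difference from 4-methylphenyl remains untested and the range stays wide. In this assay the expected move is a 6.1-fold lower number from compound 2 to compound 3 (0.78 log units; beyond the scatter). For compound 3 the estimated value is 1500 nM, with an expected range of 600 nM to 3800 nM.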

Compound 3, concentration for 50% growth inhibition: 2310 nM
Compound 3: the middle estimate sits 1.5-fold (0.19 log units) below what was measured, within the range that was stated.
By their numbers in this assay, from the lowest: compounds 1 and 3 (each within the scatter of the next); then compound 2.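

In this assay, the step with 4-ethylphenyl in place of 4-hydroxy-2-methylphenyl is a 3.9-fold lower number from compound 2 to compound 3 (0.59 log units; beyond the scatter), so this place on a carbon with a double bond to nitrogen now has two groups without a hydroxy, and compound 1 and compound 3 both give lower numbers than compound 2. The added methyl on the saturated chain carbon bound to an aromatic carbon gives a 2.0-fold higher number from compound 1 to compound 3 (0.30 log units; within the scatter), so 4-methylphenyl and 4-ethylphenyl cannot be told apart here, and this extension of the chain shows no change beyond the scatter. Among these three compounds, the only group tied to a number beyond the scatter from the others is therefore 4-hydroxy-2-methylphenyl. The data at hand offer no explanation for these differences.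

The group of compound 2 differs from the other two in both its hydroxy and its extra ring methyl, so the steps do not show which of these goes with the higher number, and 4-hydroxyphenyl and 2-methylphenyl would separate them. On these data alone, it also remains open whether a longer chain, as in 4-propylphenyl, or an amine, as in 4-aminophenyl, would keep the number near those of compound 1 and compound 3.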